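The compounds below may be only part of what the source reports. "The series", "measured", "known", "first", "only" and "open" are said of these compounds alone.

Compound 1 `O=S(=O)(c1cccc(F)c1)c1cnc2cc(F)ccc2c1-c1ccc(Cl)cc1`, compound 2 `Cc1ccc(S(=O)(=O)c2cnc3cc(F)ccc3c2-c2ccc(Cl)cc2)cc1C` and compound 3 `O=S(=O)(c1cccc(F)c1)c1cnc2cc(F)ccc2c1-c1cccc(F)c1` have been measured in an ADME assay on microsomes from liver (Homo sapiens) for metabolic stability, tested at 2.5 uM; on this read-out higher numbers stand for fast clearance and lower numbers for slow clearance. Compound 1 gives 0.98 mL/min, compound 2 gives 7.88 mL/min, and compound 3 gives 0.24 mL/min. Compound 2 arises from compound 1 by a single change, (3,4-dimethylphenyl in place of 3-fluorophenyl on a sulfonyl sulfur), and this produced an 8.0-fold higher number from compound 1 to compound 2 (0.91 log units; beyond the scatter). Compound 3 differs from compound 1 in its core, (3-fluorophenyl in place of 4-chlorophenyl on an aromatic carbon), which went with a 4.1-fold lower number from compound 1 to compound 3 (0.61 log units; beyond the scatter). Compound 4 `Cc1ccc(S(=O)(=O)c2cnc3cc(F)ccc3c2-c2cccc(F)c2)cc1C` has not yet been measured in this assay. It arises from compound 3 by the same change as before, (3,4-dimethylphenyl in place of 3-fluorophenyl on a sulfonyl sulfur), at a place described in the same words. Because compound 3 stands at 0.24 mL/min and the earlier step gave an 8.0-fold higher number from compound 1 to compound 2 (0.91 log units; beyond the scatter), a step of about a 7.1-fold higher number from compound 3 to compound 4 (0.85 log units; beyond the scatter) is expected. Compound 4 is therefore estimated at 1.7 mL/min, most likely between 0.6 mL/min and 5 mL/min.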

Compound 4, intrinsic clearance in a liver preparation (reported as CLH), per the amount of preparation that the assay uses: 3.71 mL/min
Compound 4: middle estimate off by 2.2-fold (0.34 log units), on the low side; low and high end bracket the measured number.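

In this assay, 3,4-dimethylphenyl in place of 3-fluorophenyl on a sulfonyl sulfur gave a 15-fold higher number from compound 3 to compound 4 (1.19 log units; beyond the scatter), and the step carried over from one core to the other within the scatter: the same change on two cores in this assay, an 8.0-fold higher number (0.91 log units; beyond the scatter) from compound 1 to compound 2 and a 15-fold higher number (1.19 log units; beyond the scatter) from compound 3 to compound 4, 1.9-fold (0.28 log units) apart, within the scatter of two such steps. The second change, 3-fluorophenyl in place of 4-chlorophenyl on an aromatic carbon, gave a 2.1-fold lower number from compound 2 to compound 4 (0.33 log units; beyond the scatter), and it also agreed between the two settings: the same change on two cores in this assay, a 4.1-fold lower number (0.61 log units; beyond the scatter) from compound 1 to compound 3 and a 2.1-fold lower number (0.33 log units; beyond the scatter) from compound 2 to compound 4, 1.9-fold (0.28 log units) apart, within the scatter of two such steps. This agreement rests on just these four compounds, so it does not show why the numbers move or that either change would behave the same way on another core.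

The compounds shown leave open what an amine or a carboxylic acid would do on the aromatic ring attached to the sulfonyl sulfur. They also leave open whether a longer chain there would follow the same trend.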